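The source may report more compounds than this note shows. Statements on the series, on what has been measured and on what is new or still open speak of the compounds shown alone.

Compound 1 `N#Cc1ccccc1-c1ccc(CSc2ncnc3ccccc23)cc1`: in an assay on isolated protein for inhibition of phosphodiesterase 7 (Homo sapiens), read by scintillation proximity assay and cAMP accumulation, with a stated time of 1 h (a lower number here means a stronger inhibitor, a higher number a weaker inhibitor), compound 1 gives > 100000 nM, a limit of the assay rather than a number.
Compound 2 `CC(C)c1nc(SCc2ccc(-c3ccccc3C#N)cc2)c2ccccc2n1`: compound 2 gives > 100000 nM, likewise a limit.
Compound 3 `COC(=O)c1cccc(-c2ccc(CSc3nc(C(C)C)nc4ccccc34)cc2)c1`: compound 3 gives > 100000 nM, again a limit.

Compound 3 therefore stands at the limit of > 100000 nM in this assay, at which 3 of the 3 values shown sit, and no number places it. The steps a step that the two limits leave unreadable from compound 1 to compound 2 and a step that the two limits leave unreadable from compound 2 to compound 3 are both unreadable, since each runs from one limit to another. Compound 4 `CC(C)c1nc(SCc2ccc(-c3cccc(C(=O)O)c3)cc2)c2ccccc2n1` differs from compound 3 by hydrogen in place of methyl on an oxygen next to a carbonyl group. Within the data shown here, no measured step touches this group, so nothing in the three values says in which direction the change should move the number in this assay. Compound 4 is expected to remain near the limit, with an estimated step of a number no higher from compound 3 to compound 4 (the limit leaves the size open) of no readable size. Compound 4 is estimated at 100000 nM, between 20000 nM and 500000 nM.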

Compound 4, half-maximal inhibitory concentration: 850 nM
Beside the measured number, compound 4's estimate is 120-fold (2.07 log units) above it; measured number below the stated range.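

Among these compounds, replacing methoxycarbonyl with carboxy gives an at least 110-fold lower number from compound 3 to compound 4 (2.07 log units; beyond the scatter) in this assay, so this oxygen is a place where a single change registers, whereas the steps among the earlier compounds cannot be read. Exchanging 2-cyanophenyl for 3-carboxyphenyl likewise gives an at least 110-fold lower number from compound 2 to compound 4 (2.07 log units; beyond the scatter). Among the compounds shown, only the 3-carboxyphenyl group comes with a number rather than a limit: the limit of > 100000 nM in this assay, at which 3 of the 4 values shown sit.

From the compounds shown here alone, whether this gain depends on the isopropyl group remains open. So does whether an amide or a tetrazole in place of the carboxy group would keep it.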